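This account rests on a few compounds, and the source may have more. Where it says the series, first, only, none or still open, it means among the compounds named here.

Measured compounds in an assay on HEK293 cells for agonist activity at Toll-like receptor 8 (Homo sapiens), read by reporter gene assay; a higher number here means that more compound is needed for the effect, a lower number that less compound is needed:

- compound 1 `CCCCOC(=O)n1c(N)nc2ccccc21`: "not active" (no number reported)
- compound 2 `CCCCCn1c(N)nc2ccc(C)cc21`: 7210 nM
- compound 3 `CCCCCn1c(N)nc2c(F)cccc21`: "not active" (no number reported)

Compound 3 stands without a number in this assay: for compound 3 the readout was "not active" (no number reported), and compound 1 is a second entry of the same kind, also without a number. Within the data shown here, the only compound of the three with a half-maximal effective concentration is compound 2, which gives 7210 nM in this assay. Among the measured compounds shown here, no step between two measured compounds has been worked out, so the effect of any single change on this series is not documented by a pair of numbers.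

The next compound is compound 4 `CCCCCn1c(N)nc2c(N)cccc21`. It differs from compound 3 in one place: amino in place of fluoro on an aromatic carbon. For the measured compounds named here, with compound 3 giving no number in this assay, no measured step anchors the size or direction of this change; the expectation is for a shift of uncertain size, most likely still weak, and with a substantial chance that again no number is returned. Compound 4 is estimated to give 12000 nM in this assay, expected within the range 2000 nM to 60000 nM.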

Compound 4, half-maximal effective concentration: 6600 nM
Estimate against measurement, compound 4: 1.8-fold (0.26 log units) above, within the range that was stated.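

Compound 3 gives "not active" (no number reported) and compound 4 gives 6600 nM so no step can be read between the two. No evidence at hand bears on this result. The compounds shown leave open how far amino in place of fluoro shifts the half-maximal effective concentration.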